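This account rests on a few compounds, and the source may have more. Where it says the series, first, only, none or still open, it means among the compounds named here.

In a functional assay on HeLa cells (Homo sapiens) for inhibition, read by MTT assay, with a stated time of 48 h (on this read-out lower numbers stand for stronger inhibition of growth and higher numbers for weaker inhibition of growth), compound 1 (`Cn1cc(C2CC(c3ccccc3)=NN2C(=O)c2cccnc2)c2ccccc21`) gives > 10000 nM, which is a limit of the assay and not a number. Among the measured compounds shown here, it is the only compound of the three measured to sit there: the limit of > 10000 nM in this assay, at which 1 of the 3 values shown sits. Compound 2 (`Cn1cc(C2CC(c3ccccc3)=NN2C(=O)c2ccc(Cl)nc2)c2ccccc21`), carrying 6-chloropyridin-3-yl on the carbonyl carbon, gives 8310 nM. Compound 3 (`Cn1cc(C2CC(c3ccccc3)=NN2C(=O)c2ccncc2)c2ccccc21`), carrying pyridin-4-yl there, gives 590 nM. These changes produced an at least 16-fold lower number from compound 1 to compound 3 (1.22 log units; beyond the scatter) and a 14-fold lower number from compound 2 to compound 3 (1.15 log units; beyond the scatter), but both lie at the carbonyl carbon, not where compound 4 differs.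

Compound 4 (`Cn1cc(C2CC(c3ccccc3)=NN2C(=O)c2cccnc2)c2cc(Br)ccc21`) has bromo in place of hydrogen on an aromatic carbon of the six-membered aromatic ring of carbon only, part of a fused system: bromo in place of hydrogen on an aromatic carbon. The closest measured change is of the same kind, though at another place: chloro in place of hydrogen on an aromatic carbon gave an at least 1.2-fold lower number from compound 1 to compound 2 (0.08 log units; that floor lies within the scatter). On that precedent, a small move toward stronger inhibition of growth is expected, and this assay may again return only a limit. The expected step is an at least 1.6-fold lower number from compound 1 to compound 4 (0.22 log units; that floor lies within the scatter). For compound 4 the estimated value is 6000 nM, with an expected range of 1500 nM to 20000 nM.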

Compound 4, concentration for 50% growth inhibition: 1730 nM
Compound 4: middle estimate off by 3.5-fold (0.54 log units), on the high side; the measured number falls inside the stated range.
By their numbers in this assay, from the lowest: compound 3; then compound 4; then compound 2. At a limit, above all of these: compound 1.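

In this assay, bromo in place of hydrogen on the six-membered aromatic ring of carbon only, part of the fused system, gave an at least 5.7-fold lower number from compound 1 to compound 4 (0.76 log units; beyond the scatter). Among the compounds shown here, this shows that a single heavy atom on this ring, away from the carbonyl carbon, can shift the read-out beyond the scatter, whereas the one earlier halogen step, on the pyridine side, had a floor within it, an at least 1.2-fold lower number from compound 1 to compound 2 (0.08 log units; that floor lies within the scatter). The true size of the bromo step stays unknown because compound 1 gives only a limit: the limit of > 10000 nM in this assay, at which 1 of the 4 values shown sits.

The compounds shown leave open whether a methoxy group or an amine on the same carbon would act as bromo does. They also leave open whether bromo would lower the number further when combined with the pyridin-4-yl group of compound 3.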